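The compounds below may be only part of what the source reports. "The series", "measured", "known", "first", "only" and "open" are said of these compounds alone.

Among the measured compounds shown here, in a functional assay (Homo sapiens) for inhibition, with a stated time of 72 h (a higher number here means a weaker inhibitor, a lower number a stronger inhibitor), three related compounds have numbers so far. Compound 1 `COc1cc(C(=O)c2ccc3[nH]ccc3c2)cc(OC)c1OC`, which carries a hydrogen on its aromatic nitrogen, gives 111 nM. Compound 2 `COc1cc(C(=O)c2cccc3c2ccn3C)cc(OC)c1OC` gives 26.1 nM. Compound 3 `COc1cc(C(=O)c2ccc3c(ccn3C)c2)cc(OC)c1OC` gives 12.5 nM, the lowest of the three numbers, which makes it the strongest inhibitor of this small set.

The next structure is compound 4 `CCn1ccc2cc(C(=O)c3cc(OC)c(OC)c(OC)c3)ccc21`, and it differs from compound 3 at a single place: methyl in place of hydrogen on a saturated chain carbon bound to an aromatic nitrogen. In other words, the methyl on the aromatic nitrogen becomes an ethyl.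

For the measured compounds named here, only one measured step bears on this change. Placing methyl instead of hydrogen on that aromatic nitrogen gave an 8.9-fold lower number from compound 1 to compound 3 (0.95 log units; beyond the scatter), a modest gain that lies beyond the scatter. Going by the values given here, that step shows that the nitrogen substituent can matter, but it does not show what lengthening the methyl to ethyl will do, and no measured compound carries an ethyl there. A repeat of that gain is therefore not expected. A small rise is the more cautious expectation, and the expected step is a 1.8-fold higher number from compound 3 to compound 4 (0.25 log units; within the scatter), which would not clearly exceed the scatter. The estimate for compound 4 is 22 nM, with an expected range from 8 nM to 60 nM.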

Compound 4, half-maximal inhibitory concentration: 40 nM
Compound 4: the middle estimate sits 1.8-fold (0.26 log units) below what was measured; low and high end bracket the measured number.
By their numbers in this assay, from the lowest: compound 3; then compounds 2 and 4 (each within the scatter of the next); then compound 1.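

Lengthening the methyl on the aromatic nitrogen to an ethyl gives a 3.2-fold higher number from compound 3 to compound 4 (0.51 log units; beyond the scatter) in this assay, so this position responds not only to whether the nitrogen carries a hydrogen but also to the size of the chain placed there. The ethyl still keeps part of the gain over the hydrogen, with a 2.8-fold lower number from compound 1 to compound 4 (0.44 log units; beyond the scatter) beyond the scatter, while the methyl had given an 8.9-fold lower number from compound 1 to compound 3 (0.95 log units; beyond the scatter) on its own. Among these three groups on the nitrogen, the order of the numbers therefore does not simply follow chain length: hydrogen gives the highest number, methyl the lowest and ethyl lies in between, and nothing in the data shown explains this rise from methyl to ethyl.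

Still open, on these data alone, is whether a longer chain such as propyl or butyl would raise the number further, and whether a branched group such as isopropyl, or a chain ending in an amine or a hydroxyl group, would behave like the ethyl. As far as these compounds go, it is also open whether the same change from methyl to ethyl on the core of compound 2 would give a step of similar size.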